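The source may report more compounds than this note shows. Statements on the series, on what has been measured and on what is new or still open speak of the compounds shown alone.

Measured so far in a physicochemical assay for solubility; on this read-out higher numbers stand for higher solubility and lower numbers for lower solubility:
- compound 1 `O=C(c1cccnc1)N1CCC(NS(=O)(=O)c2cc(S(=O)(=O)c3ccccc3)ccc2C(F)(F)F)CC1`: 50000 nM
- compound 2 `O=C(O)CCCC(=O)N1CCC(NS(=O)(=O)c2cc(S(=O)(=O)c3ccccc3)ccc2C(F)(F)F)CC1`: 50000 nM

Compound 2 stands level with compound 1, its nearest neighbour on these numbers, and neither value is reported as a limit. The next structure is compound 3 `CC(C)(O)CCN1CCC(NS(=O)(=O)c2cc(S(=O)(=O)c3ccccc3)ccc2C(F)(F)F)CC1`, which keeps the shared core. The change is 3-hydroxy-3-methylbutyl in place of (3-carboxypropyl)carbonyl on an amine nitrogen in a ring.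

Among the compounds with values here, one measured step bears on this, a swap of 3-carboxypropyl for pyridin-3-yl on a carbonyl carbon: no change at the digits printed from compound 1 to compound 2 (within the scatter). That step keeps the carbonyl, which compound 3 no longer carries, so no measurement covers the loss of that carbonyl. Within the data shown here, with only this step as a guide, no step beyond the scatter is expected in this assay, and no direction can be favoured. The expected step is a 1.1-fold lower number from compound 2 to compound 3 (0.05 log units; within the scatter). The range is kept wide to allow for the untested change. For compound 3 the estimated value is 45000 nM, with an expected range of 20000 nM to 60000 nM.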

Compound 3, solubility: 50000 nM
The estimate for compound 3 lay 1.1-fold (0.05 log units) below the measured number; measured number inside the range.
By their numbers in this assay, from the lowest: compounds 1, 2 and 3 (each within the scatter of the next).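

In this assay, within the data shown here, the amine nitrogen in the ring takes a group without the carbonyl at no visible cost: 3-hydroxy-3-methylbutyl in place of (3-carboxypropyl)carbonyl gives no change at the digits printed from compound 2 to compound 3 (within the scatter), so losing the carbonyl, the one feature no earlier step had touched, leaves the read-out as it was. The comparison with the aromatic acyl group reads the same, since 3-hydroxy-3-methylbutyl in place of (pyridin-3-yl)carbonyl gives no change at the digits printed from compound 1 to compound 3 (within the scatter), and the three compounds, with a carboxylic acid, a pyridine and a tertiary alcohol at the end of the substituent, now print one number, none of them reported as a limit. Nothing measured on these compounds accounts for this flat result.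

Still open, on these data alone, is whether any group on this nitrogen moves the number at all, for instance a plain butyl chain with no oxygen, or a chain ending in a dimethylamino group. A longer chain carrying the same tertiary alcohol would also show whether chain length matters here, and the shared core remains untouched by these steps.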